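The compounds below may be only part of what the source reports. "The series", "measured", "known", "first", "only" and "open" are said of these compounds alone.

Compound 1 `O=C(CSc1snnc1-c1ccc(Br)cc1Br)Nc1ccccc1` and compound 2 `Cc1ccc(NC(=O)CSc2snnc2-c2ccc(Br)cc2Br)cc1` share one core, and in an ADME assay on MT4 cells (Homo sapiens) for cytotoxicity, read by MTT assay, with a stated time of 5 days (on this read-out lower numbers stand for higher toxicity in this test and higher numbers for lower toxicity in this test), compound 1 gives 24800 nM while compound 2 gives 24000 nM. For the measured compounds named here, the single step between them, methyl in place of hydrogen on an aromatic carbon, gave a 1.0-fold lower number from compound 1 to compound 2 (0.01 log units; within the scatter), so the two compounds cannot be told apart on this read-out. Compound 2 stands at the lower of the two numbers in this assay, with compound 1 a hair above it.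

Compound 3 `Cc1ccccc1NC(=O)CSc1snnc1-c1ccc(Br)cc1Br` has not been measured. It differs from compound 2 as follows: 2-methylphenyl in place of 4-methylphenyl on an amide-type nitrogen. Going by the values given here, no measured step touches this change directly; the only step available, from compound 1 to compound 2, lies within the scatter. With nothing to suggest otherwise, compound 3 is expected to give about 24000 nM in this assay, between 11000 nM and 52000 nM, which means an expected step of no change at the digits printed from compound 2 to compound 3 (within the scatter).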

Compound 3, half-maximal cytotoxic concentration: 202000 nM
Beside the measured number, compound 3's estimate is 8.4-fold (0.93 log units) below it, outside the stated range (above it).
By their numbers in this assay, from the lowest: compounds 2 and 1 (each within the scatter of the next); then compound 3.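

In this assay the group on the amide-type nitrogen responds to where the methyl stands, not merely to whether one is present: with the same atoms, 2-methylphenyl in place of 4-methylphenyl gives an 8.4-fold higher number from compound 2 to compound 3 (0.93 log units; beyond the scatter). Methyl in place of hydrogen on an aromatic carbon, which stayed within the scatter as 4-methylphenyl, now gives an 8.1-fold higher number from compound 1 to compound 3 (0.91 log units; beyond the scatter), so the same kind of change has no measurable effect in one compound and a modest one in another. Nothing given here explains this difference.

The compounds shown leave open whether 2-chlorophenyl or 2-methoxyphenyl on the amide-type nitrogen would also raise the number, or whether this is particular to 2-methylphenyl. They also leave open where 3-methylphenyl would fall.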